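From methoxy to bromo: one swap, one open number

The source may hold more compounds than are shown below. What is called first, only, known or untested is meant among the compounds shown, and "the series" means these compounds.

Within the data shown here, in an ADME assay on Vero cells (Chlorocebus sabaeus) for cytotoxicity, read by MTT assay, with a stated time of 72 h (on this read-out lower numbers stand for an effect already at smaller amounts and higher numbers for an effect only at larger amounts of compound), compound 1 (`COc1ccc(C(=O)Nc2nc(-c3ccccn3)cs2)cc1`) gives 9200 nM and holds the lower of the two numbers so far, while compound 2 (`CC(=O)c1ccccc1C(=O)Nc1nc(-c2ccccn2)cs1`) gives 86700 nM and the gap between them lies beyond the usual scatter. Compound 3 (`O=C(Nc1nc(-c2ccccn2)cs1)c1ccc(Br)cc1`) carries bromo in place of methoxy on an aromatic carbon, para to a large group (bromo in place of methoxy on an aromatic carbon). Among the measured compounds shown here, no measured pair of compounds differs in one place only, so the data offer no guide to this swap. In this assay the expected step (a 1.0-fold lower number from compound 1 to compound 3 (0.01 log units; within the scatter)) is none beyond the scatter. For compound 3 the estimated value is 9000 nM with an expected range from 3000 nM to 30000 nM until a measurement exists.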

Compound 3, half-maximal effective concentration: 4700 nM
Estimate against measurement, compound 3: 1.9-fold (0.28 log units) above, and the stated range covers the measured number.
By their numbers in this assay, from the lowest: compounds 3 and 1 (each within the scatter of the next); then compound 2.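

Among these compounds, putting bromo in place of methoxy on this aromatic carbon, para to a large group, gives the first single-place step in this assay: a 2.0-fold lower number from compound 1 to compound 3 (0.29 log units; within the scatter). Methoxy carries a hydrogen-bond acceptor and bromo carries none, yet this read-out cannot tell the two compounds apart. Nothing at hand explains this result.

Going by these compounds, whether an amine or a carboxylic acid at this same place would also stay within the scatter remains open. So does whether a longer chain, such as butoxy, would do the same.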